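This account rests on a few compounds, and the source may have more. Where it says the series, first, only, none or still open, it means among the compounds named here.

Compound 1, `COC(=O)NC(=O)c1ccsc1NC(=O)c1ccc(S(=O)(=O)N2CCCCCC2)cc1`, was tested in a toxicity assay on Vero cells (Chlorocebus sabaeus) for cytotoxicity, read by MTT assay (on this read-out higher numbers stand for weaker inhibition and lower numbers for stronger inhibition), where compound 1 gives 9.13 ug/mL. Its closest measured neighbour is compound 2, `COC(=O)NC(=O)c1ccsc1NC(=O)c1ccc(S(=O)(=O)N2CCC(C)CC2)cc1`, and in this assay compound 2 gives 9.13 ug/mL. The one step between them, 4-methylpiperidin-1-yl in place of azepan-1-yl on a sulfonyl sulfur, gave no change at the digits printed from compound 1 to compound 2 (within the scatter), so compound 1 stands level with compound 2 on the numbers shown.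

Compound 3, `COC(=O)NC(=O)c1ccsc1NC(=O)c1ccc(S(=O)(=O)NC2CCC(F)(F)CC2)cc1`, has not yet been measured in this assay. Its change from compound 1 is (4,4-difluorocyclohexyl)amino in place of azepan-1-yl on a sulfonyl sulfur. Within the data shown here, the only measured step that bears on it is the one from compound 1 to compound 2, which also replaced the group on the sulfonyl sulfur and produced no change at the digits printed from compound 1 to compound 2 (within the scatter). That step kept a ring attached directly to the sulfonyl sulfur, whereas compound 3 carries a (4,4-difluorocyclohexyl)amino group there, a case without precedent in the measured pair, so the guidance is limited. On that basis the step from compound 1 to compound 3 is expected to be a 1.0-fold higher number from compound 1 to compound 3 (0.02 log units; within the scatter). Compound 3 is therefore estimated at 9.5 ug/mL, with a range from 4 ug/mL to 22 ug/mL.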

Compound 3, half-maximal inhibitory concentration: 49 ug/mL
Compound 3: middle estimate off by 5.2-fold (0.71 log units), on the low side; measured number outside the range, above it.
By their numbers in this assay, from the lowest: compounds 1 and 2 (each within the scatter of the next); then compound 3.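

In this assay, the group on the sulfonyl sulfur turns out to matter: (4,4-difluorocyclohexyl)amino in place of azepan-1-yl gives a 5.4-fold higher number from compound 1 to compound 3 (0.73 log units; beyond the scatter), and the same group in place of 4-methylpiperidin-1-yl gives a 5.4-fold higher number from compound 2 to compound 3 (0.73 log units; beyond the scatter). Among these compounds, the earlier pair showed only that one of these rings could replace the other with no visible effect, whereas this change shows that the number at this position can move beyond the scatter, towards weaker inhibition of the cells. This single change swaps in a ring of carbon only, adds a hydrogen-bond donor and brings in two fluorine atoms, and no measurement here shows which of these differences accounts for the shift.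

The compounds shown leave open whether the fluorine atoms play any part, since a plain cyclohexylamino group on the sulfonyl sulfur would be needed to separate them from the rest of the change. They also leave open whether a different ring joined through its nitrogen, such as morpholin-4-yl, would stay level with compound 1 or move towards compound 3.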